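Sulfone for Phenol on a Shifted Indole Core

The source may report more compounds than this note shows. Statements on the series, on what has been measured and on what is new or still open speak of the compounds shown alone.

Compound 1, `Oc1ccc(-c2cncc(-c3cc4ccc(O)cc4[nH]3)n2)cc1`, and compound 2, `CS(=O)(=O)c1ccc(-c2cncc(-c3cc4ccc(O)cc4[nH]3)n2)cc1`, share one core and differ in a single place: methylsulfonyl in place of hydroxy on an aromatic carbon. In a functional assay on HCT-116 cells (Homo sapiens) for cytotoxicity, with a stated time of 48 h (on this read-out higher numbers stand for weaker inhibition and lower numbers for stronger inhibition), compound 1 gives 3000 nM, while compound 2 gives 12000 nM, and the change is a 4.0-fold higher number from compound 1 to compound 2 (0.60 log units; beyond the scatter). Compound 3, `Oc1ccc(-c2cncc(-c3cc4cc(O)ccc4[nH]3)n2)cc1`, carries the same atoms as compound 1 joined differently; the difference between the two cores is not broken down here. In this assay compound 3 gives 6000 nM, a value that lies within the scatter of both compound 1 and compound 2, so no ordering among the three can be read from it.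

Compound 4, `CS(=O)(=O)c1ccc(-c2cncc(-c3cc4cc(O)ccc4[nH]3)n2)cc1`, has not yet been measured. It stands to compound 3 exactly as compound 2 stands to compound 1: methylsulfonyl in place of hydroxy on an aromatic carbon. The place is the same in both pairs, so this is the same change, seen twice among the compounds shown. Going by the values given here, with only one measured instance of it, the expectation for compound 4 rests on that single step and on the starting point of compound 3. Compound 4 is therefore expected to give an estimated 24000 nM in this assay, most likely falling between 10000 nM and 55000 nM. The expected step is a 4.0-fold higher number from compound 3 to compound 4 (0.60 log units; beyond the scatter), because the same change produced a 4.0-fold higher number from compound 1 to compound 2 (0.60 log units; beyond the scatter) and compound 3 begins at 6000 nM.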

Compound 4, half-maximal inhibitory concentration: 2500 nM
Estimate against measurement, compound 4: 9.6-fold (0.98 log units) above, outside the stated range (below it).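

In this assay, the swap of methylsulfonyl for hydroxy on the second core gives a 2.4-fold lower number from compound 3 to compound 4 (0.38 log units; beyond the scatter), so the number falls where it rose on the first core, and the two steps differ by more than the scatter of such steps allows: the same change on two cores in this assay, a 4.0-fold higher number (0.60 log units; beyond the scatter) from compound 1 to compound 2 and a 2.4-fold lower number (0.38 log units; beyond the scatter) from compound 3 to compound 4, 9.6-fold (0.98 log units) apart, beyond the scatter of two such steps In this series, then, neither the direction nor the size of this change carried over from one core to the other, and a step measured on one of these cores gave no reliable guide to the step on the other. Going by these compounds alone, what the result does not show is which structural difference between the two cores lies behind the split, or whether it would hold for any further core, since each core contributes only one pair and the read-out is a cell-based measure of cytotoxicity that says nothing about mechanism.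

The compounds shown leave open whether other groups in the same place, such as an amine, a carboxylic acid or a methoxy group, would also move the number in opposite directions on the two cores, or whether this split belongs to methylsulfonyl alone. Going by these compounds, it also remains open whether the same split would appear in other cell lines or at other exposure times.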